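From 4-ethylphenyl to 2,4-dimethylphenyl on a sulfonamide nitrogen

A few compounds are considered here, and "the series" means these few. Any claim that something is new, unique, unknown or untested is made for them only; others in the source may bear on it.

Within the data shown here, in a physicochemical assay for lipophilicity, at pH 7.4 (a lower number here means a more polar compound, a higher number a more lipophilic compound), compound 2 (`CCc1ccc(N(C2CCC2)S(=O)(=O)c2ccc3c(c2)C(O)CC(C2CCOCC2)O3)cc1`) gives 3.69 and holds the higher of the two numbers so far, while compound 1 (`CCc1ccc(N(C2COC2)S(=O)(=O)c2ccc3c(c2)C(O)CC(C2CCOCC2)O3)cc1`) gives 2.63 and lies beyond the scatter from it. Compound 3 (`Cc1ccc(N(C2CCC2)S(=O)(=O)c2ccc3c(c2)C(O)CC(C2CCOCC2)O3)c(C)c1`) carries 2,4-dimethylphenyl in place of 4-ethylphenyl on a sulfonamide nitrogen and has the same atoms as compound 2, joined differently. Among the measured compounds shown here, the one measured step (a number 1.06 log units higher from compound 1 to compound 2 (beyond the scatter)) is large, but it concerns cyclobutyl in place of oxetan-3-yl on a sulfonamide nitrogen and does not test this exchange. No measurement sizes the exchange directly, so compound 2 at 3.69 is the only anchor. A small downward step that stays within the scatter is expected in this assay (a number 0.09 log units lower from compound 2 to compound 3 (within the scatter)) and no clear shift is foreseen. The expected value for compound 3 is 3.6 with an estimated range from 3.2 to 4 around it.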

Compound 3, distribution coefficient: 3.77
Compound 3: the middle estimate sits 0.17 log units below what was measured; the measured number falls inside the stated range.
By their numbers in this assay, from the lowest: compound 1; then compounds 2 and 3 (each within the scatter of the next).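

In this assay, putting 2,4-dimethylphenyl in place of 4-ethylphenyl on the sulfonamide nitrogen gives a number 0.08 log units higher from compound 2 to compound 3 (within the scatter), so with cyclobutyl as the other substituent on that nitrogen, the two aryl groups cannot be told apart in this read-out. This position thus tolerates a rearrangement of the same eight carbons with no clear shift, in contrast to the large step at the other substituent on the nitrogen, a number 1.06 log units higher from compound 1 to compound 2 (beyond the scatter). Nothing available explains why the two aryl groups read alike.

The compounds shown leave open whether the two aryl groups would also read alike with oxetan-3-yl on the nitrogen. They also leave open whether a phenyl ring carrying a carboxylic acid, an amine or a longer chain would move the number beyond the scatter.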